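Dropping the chloro from the benzoyl of compound 2

This account rests on a few compounds, and the source may have more. Where it says the series, first, only, none or still open, it means among the compounds named here.

Among the measured compounds shown here, compound 2 `Cc1nnc(CN2CCCC2)n1-c1ccc(Cl)cc1C(=O)c1ccccc1Cl` is the only compound with a number in a functional assay on the whole organism (strain CF-1) with Mus musculus as the target; on this read-out lower numbers stand for an effect already at smaller amounts and higher numbers for an effect only at larger amounts of compound: compound 2 gives 18 mg/kg, and one further entry of compound 2 carries no single number. Compound 1 `Cc1nnc(CN2CCCC2)n1-c1ccc(Cl)cc1C(O)c1ccccc1` shows only limits of the assay, > 25 mg/kg; > 200 mg/kg (2 entries). Compound 3 `Cc1nnc(CN2CCCC2)n1-c1ccc(Cl)cc1C(=O)c1ccccc1` differs from compound 2 by hydrogen in place of chloro on an aromatic carbon. For the measured compounds named here, no step between two measured compounds is available, so the size of this change is open; it is expected to be modest, toward an effect only at larger amounts, and no larger than a 1.9-fold higher number from compound 2 to compound 3 (0.29 log units; within the scatter). In this assay compound 3 is expected to give 35 mg/kg, within 12 mg/kg to 100 mg/kg.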

Compound 3, dose for half-maximal effect: 4 mg/kg
Beside the measured number, compound 3's estimate is 8.8-fold (0.94 log units) above it, and the stated range ends above it.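

In this assay, the chloro of the 2-chlorophenyl group proves not to be needed for the effect: with hydrogen on that aromatic carbon the read-out moves the other way from what a loss of the group might suggest, a 4.5-fold lower number from compound 2 to compound 3 (0.65 log units; beyond the scatter), a step beyond the usual scatter. Among the compounds shown here, this is the first step that can be read at this position, and it gives the change a direction. Nothing in the data shown accounts for the size of this step. The compounds shown leave open whether fluoro, methyl or methoxy on this aromatic carbon would read like hydrogen or like chloro.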